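A few compounds are considered here, and "the series" means these few. Any claim that something is new, unique, unknown or untested is made for them only; others in the source may bear on it.

Measured compounds:
Compound 1, `Fc1ccc2nnn(Cc3ccc(-c4ccc(Cl)cc4F)nc3)c2c1`, gives 86 nM in a functional assay on cells for positive allosteric modulation of metabotropic glutamate receptor 2 (Homo sapiens), read by fluorescence and calcium flux, with a stated time of 30 min; a lower number here means that less compound is needed, a higher number that more compound is needed for the effect.
Compound 2, `Brc1cccc2c1nnn2CC1CCC1`, gives 20 nM in this assay.

Of the two measured compounds, compound 2 shows the lower number in this assay, and its gap to compound 1 lies beyond the usual scatter of repeated measurements. Compound 3, `CC(C)Cn1nnc2c(Br)cccc21`, has not yet been measured in this assay. It differs from compound 2 in one place: isopropyl in place of cyclobutyl on a saturated chain carbon bound to an aromatic nitrogen. Among the compounds with values here, no step between two measured compounds of this kind has been recorded here, so the size of this change rests on the structures alone. The two groups are close in size and in what is counted, and the step is expected to stay within the scatter, with no clear direction either way. The expected step of a 1.5-fold higher number from compound 2 to compound 3 (0.18 log units; within the scatter) is therefore small. Compound 3 is estimated to give about 30 nM, with a range from 10 nM to 90 nM.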

Compound 3, half-maximal effective concentration: 140 nM
Compound 3: the middle estimate sits 4.7-fold (0.67 log units) below what was measured; measured number outside the range, above it.
By their numbers in this assay, from the lowest: compound 2; then compounds 1 and 3 (each within the scatter of the next).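

In this assay the replacement of cyclobutyl by isopropyl on a saturated chain carbon bound to an aromatic nitrogen gives a 7.0-fold higher number from compound 2 to compound 3 (0.85 log units; beyond the scatter) and so is not a neutral exchange. Within the data shown here, this position therefore responds to a small change in which the four-membered ring is lost, something the earlier compounds could not show, since compound 1 and compound 2 differ in more than one place. Nothing available explains the size of this step.

The compounds shown leave open whether the ring itself or the size of the group matters here, a question that cyclopropyl, cyclopentyl or a longer straight chain at this place could address. They also leave open whether the same exchange would have a similar effect on the core of compound 1.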